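The source may report more compounds than this note shows. Statements on the series, on what has been measured and on what is new or still open speak of the compounds shown alone.

Compound 1 `CNc1ccc2sc(-c3c(Cl)nc(N)nc3N[C@@H]3C[C@H](CO)[C@@H](O)[C@H]3O)nc2c1`: 20000 nM
Compound 2 `CCCNc1nc(C)c(-c2nc3ccccc3s2)c(N[C@@H]2C[C@H](CO)[C@@H](O)[C@H]2O)n1`: > 25000 nM

In an ADME assay on cells (Homo sapiens) for cytotoxicity, read by polymerase chain reaction, with a stated time of 3 days (on this read-out higher numbers stand for lower toxicity in this test and lower numbers for higher toxicity in this test), compound 1 gives 20000 nM. Compound 2 reaches only a limit in this assay, > 25000 nM, which is the mark of the limit of > 25000 nM in this assay, at which 1 of the 2 values shown sits, and not a number. Compound 3 `Cc1nc(NCCNC(=O)NC(C)(C)C)nc(N[C@@H]2C[C@H](CO)[C@@H](O)[C@H]2O)c1-c1nc2ccccc2s1` differs from compound 2 in one place: ((tert-butyl)carbamoyl)amino in place of methyl on a saturated chain carbon, two bonds along the chain from a nitrogen on an aromatic ring. No step between measured compounds is shown here, and the change is expected to shift the half-maximal cytotoxic concentration by no more than the usual scatter, an estimated a number no higher from compound 2 to compound 3 (the limit leaves the size open). Compound 3 is accordingly expected at 25000 nM, within 10000 nM to 60000 nM, most probably reported again only as a limit.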

Compound 3, half-maximal cytotoxic concentration: > 25000 nM
Compound 3: a limit, no number; the forecaster's own chance of this, stated with the estimate: 70%; the middle value sits exactly at the limit.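

Compound 3 gives > 25000 nM as a limit and not a number. Within the data shown here, compound 2 also stands only as a limit, so no step between compound 2 and compound 3 can be read. From the compounds shown here alone, what stays open is whether ((tert-butyl)carbamoyl)amino in place of methyl changes the cytotoxic concentration at all.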